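Bromo to chloro swap on the aryl ketone side

This account rests on a few compounds, and the source may have more. Where it says the series, first, only, none or still open, it means among the compounds named here.

Measured compounds:
compound 1 `O=C(O)c1ccc(C(=O)/C(=C\c2ccc(Cl)c([N+](=O)[O-])c2)SCc2ccc(F)cc2)cc1` — 1000 nM
compound 2 `O=C(O)c1ccc(C(=O)/C(=C\c2ccc(Br)c([N+](=O)[O-])c2)SCc2ccc(F)cc2)cc1` — 1000 nM
compound 3 `O=C(/C(=C\c1ccc(Br)cc1)SCc1ccc(F)cc1)c1ccc(Br)cc1` — 25000 nM

In a functional assay on DU-145 cells (Homo sapiens) for inhibition, read by trypan blue exclusion, with a stated time of 96 h (a higher number here means a weaker inhibitor of growth, a lower number a stronger inhibitor of growth), compound 1 gives 1000 nM and compound 2 gives 1000 nM, while compound 3 gives 25000 nM, the highest number of the three. Going by the values given here, the one counted step among the measured compounds is chloro in place of bromo on an aromatic carbon; it reads no change at the digits printed from compound 2 to compound 1 (within the scatter). How the core of compound 3 differs from that of compound 2 is not broken down here.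

Compound 4 `O=C(/C(=C\c1ccc(Br)cc1)SCc1ccc(F)cc1)c1ccc(Cl)cc1` is not yet measured. It differs from compound 3 by chloro in place of bromo on an aromatic carbon. This is the same kind of change as from compound 2 to compound 1, not the same: there the place was also ortho to a nitro group, whereas in compound 3 no such group stands around the place.

Because no change at the digits printed from compound 2 to compound 1 (within the scatter) held within the scatter, the expectation is that compound 4 likewise shows no change at the digits printed from compound 3 to compound 4 (within the scatter), a step of little size. Compound 4 is therefore estimated at 25000 nM in this assay, with a range of 10000 nM to 60000 nM expected.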

Compound 4, concentration for 50% growth inhibition: 9000 nM
For compound 4 the middle estimate is 2.8-fold (0.44 log units) above the measured one; measured number outside the range, below it.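

In this assay, chloro in place of bromo on the (4-bromophenyl)carbonyl part gives a 2.8-fold lower number from compound 3 to compound 4 (0.44 log units; beyond the scatter). The swap therefore does not read the same on the two cores, and the absence of a step on one core did not carry over to the other: the same change on two cores in this assay, no change at the digits printed (within the scatter) from compound 2 to compound 1 and a 2.8-fold lower number (0.44 log units; beyond the scatter) from compound 3 to compound 4, 2.8-fold (0.44 log units) apart, beyond the scatter of two such steps. Going by these compounds alone, with a single pair on each core, this shows only that the step size differs between these two pairs; it does not show what sets the difference, as the halogen changes on the ring carrying the nitro group in compound 2 but on the ketone-side ring in compound 3, and the cores differ in further places.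

Open, going by these compounds, is whether the swap at the other bromo of compound 3 gives a step like that on the ring carrying the nitro group or like that on the ketone-side ring. Also open, on these data alone, is how iodo or methoxy at the same place would read, and whether a core with the carboxylic acid but no nitro group follows either pair.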